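The source may report more compounds than this note shows. Statements on the series, on what has been measured and on what is new or still open speak of the compounds shown alone.

In an assay on isolated protein for agonist activity at Bile acid receptor (Homo sapiens), read by FRET, with a stated time of 2 h (a lower number here means a smaller maximal response, a higher number a larger maximal response), compound 2 `CC(C)c1onc(-c2c(Cl)cccc2Cl)c1COc1ccc(-c2ccc3sc(C(=O)O)cc3c2)cc1` gives 77%. Compound 1 `CC(C)c1onc(-c2c(Cl)cccc2Cl)c1COc1ccc(-c2ccc3c(c2)CCCC3C(=O)O)cc1` gives 72% in this assay, and these two numbers lie within the usual scatter of each other, so neither stands apart. Compound 3 `CC(C)c1onc(-c2c(Cl)cccc2Cl)c1COc1ccc(-c2ccc3sc(C(=O)O)cc3n2)cc1` has not yet been measured. It differs from compound 2 by a group of 12 heavy atoms (8 carbon, 1 nitrogen, 2 oxygen, 1 sulfur; one five-membered aromatic ring with 1 hetero atom, one six-membered aromatic ring with 1 hetero atom) in place of a group of 12 heavy atoms (9 carbon, 2 oxygen, 1 sulfur; one five-membered aromatic ring with 1 hetero atom, one six-membered aromatic ring of carbon only), on an aromatic carbon. Among the compounds with values here, no step between measured compounds of this kind is available, so the expectation rests on the structures alone; a step no larger than the scatter is expected, a number 5 percentage points lower from compound 2 to compound 3 (within the scatter). Compound 3 is therefore estimated to give 72%, within a range from 55% to 88%.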

Compound 3, largest response reached (Emax), in percent of the reference or control that the assay uses: 53%
Compound 3: middle estimate off by 19 percentage points, on the high side; measured number outside the range, below it.
By their numbers in this assay, from the lowest: compound 3; then compounds 1 and 2 (each within the scatter of the next).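

In this assay, putting a nitrogen into the six-membered ring of the 2-carboxy-1-benzothiophen-5-yl group gives a number 24 percentage points lower from compound 2 to compound 3 (beyond the scatter), a drop beyond the scatter. The group keeps its count of heavy atoms, so this one ring atom is enough to change the maximal response, which compound 1 and compound 2 alone could not show. Nothing measured here bears on the cause of this drop.

From the compounds shown here alone, whether a methoxy group or a fluorine on this ring would also lower the response stays open, as does whether an amide in place of the carboxylic acid would preserve it.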